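The source may hold more compounds than are shown below. What is called first, only, known or untested is meant among the compounds shown, and "the series" means these compounds.

In a functional assay on K562 cells (Homo sapiens), read by MTT assay, with a stated time of 72 h (on this read-out lower numbers stand for stronger inhibition and higher numbers for weaker inhibition), little separates the three measured compounds. Compound 1 `C#Cc1cn([C@@H]2O[C@H](CO)[C@@H](O)[C@H]2O)c2nc(C)nc(N)c12` is reported only as a limit, > 20000 nM. Compound 2 `COc1nc(N)nc2c1c(-c1ccccc1)cn2[C@@H]1O[C@H](CO)[C@@H](O)[C@H]1O` is also reported only as a limit, > 20000 nM. Among the compounds with values here, compound 3 `Nc1nc2c(c(-c3ccoc3)cn2[C@@H]2O[C@H](CO)[C@@H](O)[C@H]2O)c(=O)[nH]1` gives 19600 nM, the only true number in the set, and the rest of the picture is the limit of > 20000 nM in this assay, at which 2 of the 3 values shown sit. Compound 4 `Nc1nc2c(c(-c3ccccc3)cn2[C@@H]2O[C@H](CO)[C@@H](O)[C@H]2O)c(=O)[nH]1` differs from compound 3 by having phenyl in place of furan-3-yl on an aromatic carbon. Within the data shown here, no measured step shows what such a swap does in this assay, so no change beyond the scatter is expected, in either direction. The expected step of a 1.0-fold higher number from compound 3 to compound 4 (0.01 log units; within the scatter) therefore stays small, and a report of only a limit is likely. For compound 4 the estimated value is 20000 nM, with an expected range from 8000 nM to 50000 nM.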

Compound 4, half-maximal inhibitory concentration: > 20000 nM
Compound 4 ended at the assay's limit (the forecaster's own chance of this, stated with the estimate: 70%); the middle value sits exactly at the limit.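

In this assay, within the data shown here, the swap of furan-3-yl for phenyl on an aromatic carbon gives the first measured step at this position: an at least 1.0-fold higher number from compound 3 to compound 4 (0.00 log units; that floor lies within the scatter), a floor and not a full size. That floor shows no change beyond the scatter, and it does not exclude a larger loss. Compound 4 is reported only as a limit, and the series sits still more firmly at that ceiling: the limit of > 20000 nM in this assay, at which 3 of the 4 values shown sit. As far as these compounds go, how far compound 4 truly lies from compound 3 stays open. So does whether an amine or a carboxylic acid at this position would give a true number in this assay.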